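Propargyl sulfanyl arm on the shared core

The source may report more compounds than this note shows. Statements on the series, on what has been measured and on what is new or still open speak of the compounds shown alone.

Three members of the series have numbers in a functional assay on MGC-803 cells (Homo sapiens) for inhibition, read by MTT assay, with a stated time of 72 h; on this read-out lower numbers stand for stronger inhibition and higher numbers for weaker inhibition. Compound 2 `Cc1cc(Nc2cc(-c3ccccc3)[nH]n2)n2ncnc2n1`, with hydrogen on the aromatic carbon, gives 21700 nM. Compound 1 `Cc1cc(Nc2cc(-c3ccccc3)[nH]n2)n2nc(SCCCc3ccccc3)nc2n1` gives 6510 nM, and compound 3 `Cc1cc(Nc2cc(-c3ccccc3)[nH]n2)n2nc(SCc3cccc4ccccc34)nc2n1` gives 3120 nM, the lowest of the three. Compound 4 `C#CCSc1nc2nc(C)cc(Nc3cc(-c4ccccc4)[nH]n3)n2n1` is compound 3 with ethynyl in place of naphthalen-1-yl on a saturated chain carbon bound to a sulfur. Among the measured compounds shown here, two measured steps bear on this change. The step of a 3.3-fold higher number from compound 1 to compound 2 (0.52 log units; beyond the scatter) shows that removing the whole sulfanyl arm raises the number, and the step of a 2.1-fold lower number from compound 1 to compound 3 (0.32 log units; beyond the scatter) shows that enlarging the aromatic group on that arm lowers it; ethynyl is smaller than either group. Compound 4 is therefore expected to sit between compound 1 and compound 2. Compound 4 is estimated at 9000 nM, with a range from 4000 nM to 20000 nM, an expected step of a 2.9-fold higher number from compound 3 to compound 4 (0.46 log units; beyond the scatter).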

Compound 4, half-maximal inhibitory concentration: 13400 nM
Compound 4: middle estimate off by 1.5-fold (0.17 log units), on the low side; measured number inside the range.
By their numbers in this assay, from the lowest: compound 3; then compound 1; then compounds 4 and 2 (each within the scatter of the next).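

In this assay, propargylsulfanyl in place of hydrogen on an aromatic carbon does not separate the two compounds, with a 1.6-fold lower number from compound 2 to compound 4 (0.21 log units; within the scatter) as the step. The aromatic end of the arm counts at this position: ethynyl gives a 2.1-fold higher number from compound 1 to compound 4 (0.31 log units; beyond the scatter) against phenethyl and a 4.3-fold higher number from compound 3 to compound 4 (0.63 log units; beyond the scatter) against naphthalen-1-yl, so among these four compounds the lower numbers go with an aromatic group on the arm, and none goes against this.

From the compounds shown here alone, whether a plain hexyl chain or an aminoethyl arm on the sulfur would behave like the aromatic arms stays open. Nothing available explains why the arm shifts these numbers.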